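Swapping trifluoromethyl for nitro on a shared core

The compounds below may be only part of what the source reports. "The series", "measured", "known", "first", "only" and "open" are said of these compounds alone.

Three compounds share one core and carry a substituted aromatic ring on the amide. Compound 1 `O=C(Nc1ccccc1C(F)(F)F)c1ccc2cccc(O)c2n1` gives 2.5 in a physicochemical assay for lipophilicity, read by HPLC; on this read-out lower numbers stand for lower lipophilicity and higher numbers for higher lipophilicity. Compound 3 `O=C(Nc1ccccc1[N+](=O)[O-])c1ccc2cccc(O)c2n1` gives 2.5 in this assay. The step of no change at the digits printed from compound 1 to compound 3 (within the scatter) follows the change (nitro in place of trifluoromethyl on an aromatic carbon). Compound 2 `O=C(Nc1cccc(C(F)(F)F)c1)c1ccc2cccc(O)c2n1` gives 2.5 in this assay; the difference between the cores of compound 1 and compound 2 is not broken down here.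

Compound 4 `O=C(Nc1cccc([N+](=O)[O-])c1)c1ccc2cccc(O)c2n1` has not yet been measured. It arises from compound 2 by nitro in place of trifluoromethyl on an aromatic carbon, the same kind of change as that from compound 1 to compound 3, but here the group sits meta to a large group rather than ortho to a large group. Because no change at the digits printed from compound 1 to compound 3 (within the scatter), the expected step of no change at the digits printed from compound 2 to compound 4 (within the scatter) is estimated to be just as small. Compound 4 is therefore expected to give about 2.5 in this assay.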

Compound 4, partition coefficient: 2.5
Beside the measured number, compound 4's estimate shows no gap at the digits printed, and the stated range covers the measured number.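

In this assay, nitro in place of trifluoromethyl on an aromatic carbon gives no change at the digits printed from compound 2 to compound 4 (within the scatter) with the group meta to a large group, and the same change gives no change at the digits printed from compound 1 to compound 3 (within the scatter) on the other core. So the change carries over between these two cores, and in both pairs the two groups cannot be told apart on this read-out. This does not show that it would carry over to any further core, and nothing shown explains why the two groups read alike.

Still open, on these data alone, is whether an amine, a carboxylic acid or a longer chain in the same place would read level with compound 2 and compound 4. The compounds shown also leave open whether nitro and trifluoromethyl stay level on any read-out other than this assay in this series.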